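Methoxy for Methyl on a Growth Inhibitor

The compounds below may be only part of what the source reports. "The series", "measured", "known", "first", "only" and "open" are said of these compounds alone.

Of the compounds shown here, two have numbers so far in a functional assay on RS4-11 cells (Homo sapiens) for inhibition, read by CCK-8 assay, with a stated time of 48 h, tested at 20 uM (on this read-out lower numbers stand for less inhibition of growth and higher numbers for more inhibition of growth at the one concentration tested), for this small series. Compound 1 `COc1ccc(S(=O)(=O)Oc2ccccc2/C=C(\C#N)C(=O)Nc2nnc(Cc3cccc(F)c3)s2)cc1` gives 74% there, and compound 2 `Cc1ccc(S(=O)(=O)Oc2ccccc2/C=C(\C#N)C(=O)Nc2nnc(Cc3ccc(Cl)cc3)s2)cc1` gives 69% in the same test. These two values lie within the usual scatter of repeated measurements, so compound 2 stands level with compound 1 and neither can be ranked over the other.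

Compound 3 `COc1ccc(S(=O)(=O)Oc2ccccc2/C=C(\C#N)C(=O)Nc2nnc(Cc3ccc(Cl)cc3)s2)cc1` has not yet been measured. It departs from compound 2 in one place (methoxy in place of methyl on an aromatic carbon), with methoxy in place of methyl on an aromatic carbon, para to a large group. This turns 4-methylphenyl into 4-methoxyphenyl while the rest of the molecule stays the same.

Among the measured compounds shown here, no measured pair shows this exact swap, so the data give no direct guide to its size. For the measured compounds named here, the only hint is that compound 1 at 74% and compound 2 at 69% sit within the scatter of each other. In this assay no step beyond the scatter is expected, and the estimated move a number 3 percentage points higher from compound 2 to compound 3 (within the scatter) stays inside it. Compound 3 is estimated to give 72% with a likely range of 60% to 83%.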

Compound 3, percent growth inhibition at one concentration: 77%
Beside the measured number, compound 3's estimate is 5 percentage points below it, within the range that was stated.
By their numbers in this assay, from the lowest: compounds 2, 1 and 3 (each within the scatter of the next).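

Among the compounds shown here, this pair gives the first direct reading of 4-methylphenyl changed to 4-methoxyphenyl: in this assay the swap gives a number 8 percentage points higher from compound 2 to compound 3 (within the scatter) and so leaves the two compounds level. For the compounds shown here, the position therefore accepts methoxy, with its extra oxygen, as well as methyl, and the single swap does not separate them. Compound 3 also allows a second reading, where 4-chlorophenyl in place of 3-fluorophenyl on a saturated chain carbon bound to an aromatic carbon gives a number 3 percentage points higher from compound 1 to compound 3 (within the scatter) and again separates nothing, while no measurement is available that could explain any of these values.

From the compounds shown here alone, only methyl and methoxy appear at this position, so it remains open whether an amine, a carboxylic acid or a longer chain such as butoxy there would shift growth inhibition beyond the usual scatter. All three compounds also stand close together at one tested concentration, which leaves open whether a hydrogen atom in place of the methoxy would show that this position matters at all.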